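Swapping an open amine chain for a pyrrolidine

The source may report more compounds than this note shows. Statements on the series, on what has been measured and on what is new or still open speak of the compounds shown alone.

compound 1 `CN[C@@H](C)c1ccc(N2CC[C@H](NS(=O)(=O)c3ccc4cc(Cl)ccc4c3)C2=O)c(F)c1` gives 1.6 mL/min/kg
compound 2 `CN(C)[C@H]1CCc2cc(N3CC[C@H](NS(=O)(=O)c4ccc5cc(Cl)ccc5c4)C3=O)ccc21` gives 6 mL/min/kg
compound 3 `CNC1CCc2cc(N3CC[C@H](NS(=O)(=O)c4ccc5cc(Cl)ccc5c4)C3=O)ccc21` gives 2.5 mL/min/kg

All three numbers come from an in vivo ADME assay on the whole organism (plasma, strain Sprague-Dawley) for pharmacokinetics, with Rattus norvegicus as the target (on this read-out higher numbers stand for fast clearance and lower numbers for slow clearance), and show how quickly each compound is removed from the blood of the animal. Compound 1 with 1.6 mL/min/kg cannot be told apart from compound 3 with 2.5 mL/min/kg. Repeat measurements scatter by about that much. Compound 2 with 6 mL/min/kg stands higher than compound 1 by more than the scatter, so compound 1 sits at the slow end of this small set.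

Compound 4 `O=C1[C@@H](NS(=O)(=O)c2ccc3cc(Cl)ccc3c2)CCN1c1ccc([C@@H]2CCCN2)cc1F` keeps the core of compound 1 and changes one group: pyrrolidin-2-yl in place of 1-(methylamino)ethyl on an aromatic carbon. Among the measured compounds shown here, no pair of measured compounds differs by this swap or by any other single change, so the data offer no direct guide. All that remains is the spread of the three values, which is narrow. The expectation is therefore a small rise, a 1.6-fold higher number from compound 1 to compound 4 (0.19 log units; within the scatter) and so not beyond the scatter. Compound 4 is estimated at 2.5 mL/min/kg in a range from 1 mL/min/kg to 7 mL/min/kg for now.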

Compound 4, clearance: 2.8 mL/min/kg
Compound 4: middle estimate off by 1.1-fold (0.05 log units), on the low side, within the range that was stated.
By their numbers in this assay, from the lowest: compounds 1, 3 and 4 (each within the scatter of the next); then compound 2.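

In this assay, among the compounds shown here, the swap of the open 1-(methylamino)ethyl for the ring of pyrrolidin-2-yl on this aromatic carbon gives a 1.8-fold higher number from compound 1 to compound 4 (0.24 log units; within the scatter), the first direct comparison at this position. For this one pair, then, tying the amine chain into a five-membered ring, with the count of hydrogen-bond donors and acceptors unchanged, produces no difference that can be separated from the ordinary spread of repeat measurements. No measured information is available to explain the outcome of this swap.

The compounds shown leave open whether a six-membered piperidin-2-yl ring, or a pyrrolidin-2-yl carrying a methyl group on its nitrogen, would also stay within the scatter of compound 1. They also leave open how the opposite stereocentre in the pyrrolidin-2-yl group would read, and whether the same swap would give a similar step with a hydrogen in place of the fluoro group.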